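The source may hold more compounds than are shown below. What is called first, only, known or untested is meant among the compounds shown, and "the series" means these compounds.

Compound 1 `CCCc1c(OC)nc2nc(-c3nnc(C)o3)cn2c1C`: 10 mg/kg
Compound 2 `CCc1c(OC)nc2nc(-c3nc(C)cs3)cn2c1C`: > 50 mg/kg

In a functional assay on the whole organism with Rattus norvegicus as the target (on this read-out lower numbers stand for an effect already at smaller amounts and higher numbers for an effect only at larger amounts of compound), compound 1 gives 10 mg/kg. For compound 2 only a limit is known in this assay, > 50 mg/kg, and it sits at the limit of > 50 mg/kg in this assay, at which 1 of the 2 values shown sits, rather than at a number of its own. Compound 3 `CCCc1c(OC)nc2nc(-c3nc(C)cs3)cn2c1C` has not yet been measured in this assay. It differs from compound 2 by methyl in place of hydrogen on a saturated chain carbon, two bonds along the chain from an aromatic carbon. Among the compounds with values here, no measured pair shows this change alone, and the one numbered value belongs to compound 1, whose other groups differ from those of compound 2. In this assay no step beyond the scatter is expected, and compound 3 is estimated at 50 mg/kg, within 15 mg/kg to 150 mg/kg. The change expected amounts to a number no higher from compound 2 to compound 3 (the limit leaves the size open).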

Compound 3, minimum effective dose: > 50 mg/kg
Compound 3 gave a limit, no number (the forecaster's own chance of this, stated with the estimate: 60%); the middle value sits exactly at the limit.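

With the propyl chain held constant, 4-methyl-1,3-thiazol-2-yl in place of 5-methyl-1,3,4-oxadiazol-2-yl on an aromatic carbon now reads as a single change: in this assay it gives an at least 5.0-fold higher number from compound 1 to compound 3 (0.69 log units; beyond the scatter). Propyl alone therefore does not bring a number alongside the 4-methyl-1,3-thiazol-2-yl group. The step for methyl in place of hydrogen on the chain cannot be read, as both values are limits: the limit of > 50 mg/kg in this assay, at which 2 of the 3 values shown sit.

Going by these compounds, it remains open whether a butyl chain or an amine on this chain would give a number in this assay. On these data alone, the effect of this chain change alongside 5-methyl-1,3,4-oxadiazol-2-yl also remains open.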